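This account rests on a few compounds, and the source may have more. Where it says the series, first, only, none or still open, it means among the compounds named here.

Compound 1 `CCN(CC)C(=O)CC1CCc2cc(OC)c(OC)cc21` and compound 2 `COc1cc2c(cc1OC)C(CC(=O)NC(C)C)CC2` share one core and differ only at the amide nitrogen. In a functional assay on the whole organism (strain Wistar) for inhibition, with Rattus norvegicus as the target, read by paw edema, with stated times of 60 min and 1 h, at a dose of 100 mg/kg by the oral route (a higher number here means more inhibition at the dose given (going by the name of the read-out), a lower number less inhibition), compound 1 gives 31.3%. In this assay compound 2 gives 31.3%, so the step of no change at the digits printed from compound 1 to compound 2 (within the scatter), which put isopropylamino in place of diethylamino on a carbonyl carbon, stays within the scatter, and compound 2 stands level with compound 1 on these numbers. Compound 3 `CCCCCCNC(=O)CC1CCc2cc(OC)c(OC)cc21` is the next member, differing from compound 2 by hexyl in place of isopropyl on an amide-type nitrogen. Going by the values given here, the one measured step that bears on it, the exchange of one alkyl substitution pattern at the amide nitrogen for another between compound 1 and compound 2, gave no change beyond the scatter, so a further exchange of alkyl at the same nitrogen is expected to move this assay little in either direction. The expected step from compound 2 to compound 3 is therefore a number 0.3 percentage points lower from compound 2 to compound 3 (within the scatter). Compound 3 is estimated at 31%, in the range 15% to 48%.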

Compound 3, a percentage reported as inhibition, in the whole organism at one dose (the size of the read-out at that dose, not a potency): 47.6%
Compound 3: the middle estimate sits 16.6 percentage points below what was measured; the measured number falls inside the stated range.
By their numbers in this assay, from the lowest: compounds 1 and 2 (each within the scatter of the next); then compound 3.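

At the amide-type nitrogen, the alkyl group can matter in this assay: hexyl in place of isopropyl gives a number 16.3 percentage points higher from compound 2 to compound 3 (beyond the scatter), whereas the earlier exchange of alkyl groups at this nitrogen gave no change at the digits printed from compound 1 to compound 2 (within the scatter). Hexylamino in place of diethylamino on a carbonyl carbon gives a number 16.3 percentage points higher from compound 1 to compound 3 (beyond the scatter), so compound 3 stands clear of both earlier compounds, whichever of them it is compared with. No measurement available here accounts for this rise.

With hexyl as the only longer group, the compounds shown leave open whether a longer chain such as octyl would raise the number further or lower it. Also open, as far as these compounds go, is whether a hexyl chain ending in an amine or a carboxylic acid would hold the level of compound 3.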